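A Second Chloro Group and Solubility

This account rests on a few compounds, and the source may have more. Where it says the series, first, only, none or still open, it means among the compounds named here.

Compound 1 `O=C(Nc1ccc(F)cc1Cl)c1cc(Cl)ccc1O` gives 1.2 ug/mL in a physicochemical assay for solubility; a lower number here means a less soluble compound, a higher number a more soluble compound. Compound 2 `O=C(Nc1c(Cl)cc(F)cc1Cl)c1cc(Cl)ccc1O` differs from it by chloro in place of hydrogen on an aromatic carbon. In this assay compound 2 gives only a limit, > 49 ug/mL, so the true number is not known. That change made an at least 40-fold higher number from compound 1 to compound 2 (1.61 log units; beyond the scatter). Compound 3 `O=C(Nc1ccc(C(F)(F)F)cc1)c1cc(Cl)ccc1O` has a core whose difference from compound 1 is not broken down here. In this assay compound 3 also gives only a limit, < 1 ug/mL. Compound 4 `O=C(Nc1ccc(C(F)(F)F)cc1Cl)c1cc(Cl)ccc1O` is not yet measured; it differs from compound 3 by chloro in place of hydrogen on an aromatic carbon. The surroundings differ: in compound 2 the chloro sits meta to a chloro group and meta to a fluoro group, in compound 4 meta to a trifluoromethyl group, so this is the same kind of change, not the same change. A step of similar size is expected, an at least 15-fold higher number from compound 3 to compound 4 (1.17 log units; beyond the scatter), resting on an at least 40-fold higher number from compound 1 to compound 2 (1.61 log units; beyond the scatter). Compound 4 is therefore expected to give 15 ug/mL, between 1.5 ug/mL and 60 ug/mL.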

Compound 4, solubility: < 1 ug/mL
Compound 4 ended at the assay's limit; the forecaster's own chance of this, stated with the estimate: 25%; middle value at least 15-fold (1.17 log units) from the limit.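

In this assay compound 4 gives < 1 ug/mL as a limit of the assay, not a number. The added chloro did not show on this core the rise it showed on the core of compound 1, yet a failure to carry over is not shown either, because the step between compound 3 and compound 4 cannot be read: the limit of < 1 ug/mL in this assay, at which 2 of the 4 values shown sit. Trifluoromethyl in place of fluoro gives an at least 1.2-fold lower number from compound 1 to compound 4 (0.07 log units; that floor lies within the scatter) and that floor settles little.

The compounds shown leave open whether chloro would give a readable step on a core whose values lie inside the range of this assay. They also leave open how an amine or a carboxylic acid in place of the chloro would read.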